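The source may report more compounds than this note shows. Statements on the series, on what has been measured and on what is new or still open speak of the compounds shown alone.

Measured in a functional assay on A2780 cells (Homo sapiens) for antiproliferative activity, read by fluorescence, with a stated time of 72 h; a lower number here means a stronger inhibitor, a higher number a weaker inhibitor:
- compound 1 `CC(C)(C)C(=O)N1Cc2c(NC(=O)c3cccnc3)n[nH]c2C1(C)C`: 690 nM
- compound 2 `CCN1CCC(C(=O)N2Cc3c(NC(=O)CC(C)C)n[nH]c3C2(C)C)CC1`: 410 nM
- compound 3 `CN1CCC(C(=O)N2Cc3c(NC(=O)Nc4cccc(F)c4)n[nH]c3C2(C)C)CC1`: 350 nM

Compound 1 lies within the usual scatter of both compound 2 and compound 3, so these numbers do not separate it from either. Compound 4 `CC(C)(C)C(=O)N1Cc2c(NC(=O)c3ccncc3)n[nH]c2C1(C)C` differs from compound 1 in one place: pyridin-4-yl in place of pyridin-3-yl on a carbonyl carbon. Pyridin-4-yl stands in place of pyridin-3-yl on a carbonyl carbon, with the same atoms joined differently. Among the compounds with values here, no measured pair here differs in one place alone, so the data offer no direct guide to such a change. In this assay, no shift beyond the scatter is expected, in either direction. The expected change is small: a 1.2-fold lower number from compound 1 to compound 4 (0.06 log units; within the scatter). The estimate for compound 4 is 600 nM, with an expected range of 250 nM to 1400 nM.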

Compound 4, half-maximal inhibitory concentration: 110 nM
The estimate for compound 4 lay 5.5-fold (0.74 log units) above the measured number; the measured number lies below the stated range.
By their numbers in this assay, from the lowest: compound 4; then compounds 3, 2 and 1 (each within the scatter of the next).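

In this assay, pyridin-4-yl in place of pyridin-3-yl on a carbonyl carbon gives a 6.3-fold lower number from compound 1 to compound 4 (0.80 log units; beyond the scatter). Within the data shown here, at this position, then, the way the same atoms are joined can matter, which the earlier compounds could not show, as no two of them differed in one place alone. Nothing available explains this step.

Going by these compounds, how pyridin-2-yl or a plain phenyl ring on the same carbonyl carbon would compare remains open. So does whether this swap would give a similar step on other compounds.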